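Chloro in place of hydrogen on compound 3

The compounds below may be only part of what the source reports. "The series", "measured", "known", "first", "only" and "open" are said of these compounds alone.

Among the compounds with values here, in a functional assay on DU-145 cells (Homo sapiens) for inhibition, read by MTT assay, with a stated time of 72 h (on this read-out lower numbers stand for stronger inhibition and higher numbers for weaker inhibition), compound 3 `O=C1C=C(N2CCN(c3ccccc3)CC2)C(=O)c2ccccc21` gives 9900 nM, the lowest number so far. Compound 2 `COc1ccc(N2CCN(C3=CC(=O)c4ccccc4C3=O)CC2)cc1` gives 46100 nM. Compound 1 `O=C1C=C(N2CCN(c3ccc(Br)cc3)CC2)C(=O)c2ccccc21` gives > 50000 nM, which is a limit of the assay and not a number.

Compound 4 `O=C1C=C(N2CCN(c3cccc(Cl)c3)CC2)C(=O)c2ccccc21` carries chloro in place of hydrogen on an aromatic carbon, meta to a large group: chloro in place of hydrogen on an aromatic carbon.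

Within the data shown here, two measured steps bear on this change, both ending in hydrogen on an aromatic carbon. With methoxy leaving, the data show a 4.7-fold lower number from compound 2 to compound 3 (0.67 log units; beyond the scatter). With bromo leaving, they show an at least 5.0-fold lower number from compound 1 to compound 3 (0.70 log units; beyond the scatter), a step that rests on (the limit of > 50000 nM in this assay, at which 1 of the 3 values shown sits). Read in reverse, adding either group to compound 3 raises the number. Among the measured compounds shown here, no measured compound carries chloro, so the transfer is uncertain. A modest rise is expected in this assay, in the same direction.

The expected step is a 2.2-fold higher number from compound 3 to compound 4 (0.35 log units; beyond the scatter).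

The estimated value for compound 4 is 22000 nM, with an expected range of 7000 nM to 50000 nM.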

Compound 4, half-maximal inhibitory concentration: 8300 nM
Compound 4: the middle estimate sits 2.7-fold (0.42 log units) above what was measured; the measured number falls inside the stated range.
By their numbers in this assay, from the lowest: compounds 4 and 3 (each within the scatter of the next); then compound 2. At a limit, above all of these: compound 1.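

In this assay, within the data shown here, chloro on this aromatic carbon is the first added group that leaves the number within the scatter, with a 1.2-fold lower number from compound 3 to compound 4 (0.08 log units; within the scatter). The 3-chlorophenyl group therefore does not share the rise seen with 4-methoxyphenyl, as a 5.6-fold lower number from compound 2 to compound 4 (0.74 log units; beyond the scatter) shows. The comparison with 4-bromophenyl gives an at least 6.0-fold lower number from compound 1 to compound 4 (0.77 log units; beyond the scatter), a step that rests on a limit of the assay and not on a number: the limit of > 50000 nM in this assay, at which 1 of the 4 values shown sits.

Group and place change together in both of these larger steps, so the compounds shown do not tell whether the gap follows from chloro itself or from where it sits. Also open, from the compounds shown here alone, is whether an amine or a carboxylic acid on this aromatic carbon would keep the number close to that of compound 3.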